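This account rests on a few compounds, and the source may have more. Where it says the series, first, only, none or still open, it means among the compounds named here.

Compound 1 `Cc1cccc(OC(c2ccc(C(F)(F)F)cc2)C2CCN(C(C)CCNC(=O)c3c(Cl)cncc3Cl)CC2)n1` and compound 2 `CC(CCNC(=O)c1c(Cl)cncc1Cl)N1CCC(C(Oc2ccccc2C(F)(F)F)c2ccc(C(F)(F)F)cc2)CC1` share one core and differ only in the aryl group on the oxygen on a saturated carbon. In an ADME assay on PBMC cells (Homo sapiens) for cytotoxicity (on this read-out higher numbers stand for lower toxicity in this test and lower numbers for higher toxicity in this test), compound 1 gives 6700 nM, and compound 2 gives 12500 nM. The step of a 1.9-fold higher number from compound 1 to compound 2 (0.27 log units; within the scatter) is the only one measured so far, and it lies within the scatter, so the two numbers cannot be told apart; compound 2 simply stands beside compound 1 on this read-out.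

Compound 3 `CC(CCNC(=O)c1c(Cl)cncc1Cl)N1CCC(C(Oc2ccccc2C#N)c2ccc(C(F)(F)F)cc2)CC1` is the next case. It differs from compound 2 by cyano in place of trifluoromethyl on an aromatic carbon, the exchange sitting on an aromatic carbon of a six-membered aromatic ring of carbon only, ortho to a large group. Among the compounds with values here, no measured step exchanges these two groups, and the one step that exists, the exchange of the whole aryl group between compound 1 and compound 2, stayed within the scatter. Nothing in the data therefore points to a step beyond the scatter in this assay in either direction, and the estimated step of a 1.0-fold lower number from compound 2 to compound 3 (0.02 log units; within the scatter) is expected to be small. For compound 3 the expected value is 12000 nM, with a range from 5000 nM to 30000 nM.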

Compound 3, half-maximal cytotoxic concentration: 17000 nM
The estimate for compound 3 lay 1.4-fold (0.15 log units) below the measured number, and the stated range covers the measured number.
By their numbers in this assay, from the lowest: compounds 1, 2 and 3 (each within the scatter of the next, the first and the last beyond it).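

On the aromatic carbon ortho to a large group, the exchange of trifluoromethyl for cyano gives a 1.4-fold higher number from compound 2 to compound 3 (0.13 log units; within the scatter) in this assay and so leaves the two compounds indistinguishable on this read-out. The aryl group on the oxygen on a saturated carbon now gives its first step beyond the scatter, a 2.5-fold higher number from compound 1 to compound 3 (0.40 log units; beyond the scatter), a modest one, while compound 2, which carries 2-(trifluoromethyl)phenyl at that place, cannot be told apart from compound 1 or from compound 3. Nothing measured on these compounds bears on why either step has the size it has.

The compounds shown leave open whether the modest step from the 6-methylpyridin-2-yl group to the 2-cyanophenyl group belongs to the cyano group itself or to the change of the whole aryl group, as these two compounds differ in both at once. They also leave open how this assay would read with an amine, a carboxylic acid or a methoxy group on that same aromatic carbon, or with a plain phenyl group on the oxygen.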